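From pyridin-3-yl to 2-nitrophenyl on the side chain

The source may hold more compounds than are shown below. What is called first, only, known or untested is meant among the compounds shown, and "the series" means these compounds.

Of the compounds shown here, three have so far been tested in a functional assay on HL-60 cells (Homo sapiens) for cytotoxicity, read by WST assay, with a stated time of 48 h (on this read-out lower numbers stand for stronger inhibition and higher numbers for weaker inhibition), for this comparison.

compound 1 `CCCCCC/C=C/C[C@H]1C[C@@H]([C@@H](O)c2ccccc2)CO[C@@H]1c1ccccc1` gives 4990 nM 
compound 2 `COc1ccccc1/C=C/C[C@H]1C[C@@H]([C@@H](O)c2ccccc2)CO[C@@H]1c1ccccc1` gives 10100 nM 
compound 3 `O[C@@H](c1ccccc1)[C@H]1CO[C@H](c2ccccc2)[C@@H](C/C=C/c2cccnc2)C1` gives > 100000 nM as a limit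

Compound 3 stands only at a limit (the limit of > 100000 nM in this assay, at which 1 of the 3 values shown sits) and has no measured number. Compound 4 `O=[N+]([O-])c1ccccc1/C=C/C[C@H]1C[C@@H]([C@@H](O)c2ccccc2)CO[C@@H]1c1ccccc1` carries 2-nitrophenyl in place of pyridin-3-yl on a double-bonded chain carbon bound to a double-bonded chain carbon. Exchanging hexyl for 2-methoxyphenyl was a modest step (a 2.0-fold higher number from compound 1 to compound 2 (0.31 log units; beyond the scatter)). The steps to pyridin-3-yl were greater (an at least 20-fold higher number from compound 1 to compound 3 (1.30 log units; beyond the scatter)) and (an at least 9.9-fold higher number from compound 2 to compound 3 (0.99 log units; beyond the scatter)). The 2-nitrophenyl group is a six-membered aromatic ring of carbon only, so compound 4 is expected to resemble compound 2 at 10100 nM in this assay. In this assay an estimated at least 10-fold lower number from compound 3 to compound 4 (1.00 log units; beyond the scatter) is therefore expected, toward lower numbers. The estimated value for compound 4 is 10000 nM, with an expected range from 3000 nM to 35000 nM overall.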

Compound 4, half-maximal inhibitory concentration: 7250 nM
Compound 4: middle estimate off by 1.4-fold (0.14 log units), on the high side, within the range that was stated.
By their numbers in this assay, from the lowest: compounds 1, 4 and 2 (each within the scatter of the next, the first and the last beyond it). At a limit, above all of these: compound 3.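

In this assay, the exchange of pyridin-3-yl for 2-nitrophenyl gives an at least 13-fold lower number from compound 3 to compound 4 (1.13 log units; beyond the scatter), so an aromatic ring at this place does not by itself bring the loss seen with pyridin-3-yl. Compound 3 stands only at a limit: the limit of > 100000 nM in this assay, at which 1 of the 4 values shown sits. Nitro in place of methoxy stays within the scatter, with a 1.4-fold lower number from compound 2 to compound 4 (0.14 log units; within the scatter), and so does 2-nitrophenyl in place of hexyl, with a 1.5-fold higher number from compound 1 to compound 4 (0.16 log units; within the scatter).

On these data alone, whether the ring nitrogen alone sets compound 3 apart remains open. So does how an unsubstituted phenyl ring or an amine on the aromatic ring would read here.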